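Thiadiazole series: phenyl for methylpyrazolyl, lipophilicity

A few compounds are considered here, and "the series" means these few. Any claim that something is new, unique, unknown or untested is made for them only; others in the source may bear on it.

Of the compounds shown here, two have numbers so far in a physicochemical assay for lipophilicity, at pH 7.4; a higher number here means a more lipophilic compound, a lower number a more polar compound. Compound 1 `Cc1c2c(nn1-c1nnc(-c3ccc(OC(C)C)c(C#N)c3)s1)CCN(CCC(=O)O)C2` gives 2.76 in this assay, and compound 2 `CC(C)Oc1ccc(-c2nnc(-c3ccnn3C)s2)cc1Cl` gives 7.04. Compound 2 thus stands at the top of the two measured values, and the gap to compound 1 lies well beyond the scatter of repeated measurements. Compound 3 `CC(C)Oc1ccc(-c2nnc(-c3ccccc3)s2)cc1Cl` has not been measured yet. It differs from compound 2 in one place: phenyl in place of 1-methyl-1H-pyrazol-5-yl on an aromatic carbon. Going by the values given here, no step between measured compounds involves a change of this kind, so the expectation rests on the structural change alone. The step from compound 2 to compound 3 is expected to be a moderate rise, estimated at a number 0.56 log units higher from compound 2 to compound 3 (beyond the scatter), going beyond the scatter. For compound 3 the expected value in this assay is 7.6, with a range from 6.8 to 8.4, and given how high compound 2 already sits, a reading reported only as a limit is a real possibility.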

Compound 3, distribution coefficient: 8.65
Beside the measured number, compound 3's estimate is 1.05 log units below it, outside the stated range (above it).
By their numbers in this assay, from the lowest: compound 1; then compound 2; then compound 3.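

In this assay, going by these compounds alone, phenyl in place of 1-methyl-1H-pyrazol-5-yl on an aromatic carbon of the shared core gives a number 1.61 log units higher from compound 2 to compound 3 (beyond the scatter), a large step and the first one-place comparison. This position therefore strongly moves the read-out, even though the group that leaves and the group that enters both have 6 heavy atoms and no net charge; the counted differences are the 2 nitrogen and 2 hydrogen-bond acceptors that leave with the 1-methyl-1H-pyrazol-5-yl. No measured evidence on the origin of this step is at hand.

From the compounds shown here alone, with a single pair, it remains open how much of the step would carry over to another core, such as that of compound 1. Going by these compounds, it also remains open where a pyridyl ring, or a phenyl bearing a methoxy group, would fall at this position.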